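A Fluoro for Methyl Change on Compound 1

This account rests on a few compounds, and the source may have more. Where it says the series, first, only, none or still open, it means among the compounds named here.

Measured values in an ADME assay on MT4 cells (Homo sapiens) for cytotoxicity, read by spectrophotometry, with a stated time of 5 days (a lower number here means that less compound is tolerated, a higher number that more compound is tolerated), are as follows
Compound 1 `CCn1cc(C(=O)O)c(=O)c2cc(F)c(N3CCN(CN4C(=O)/C(=N\NC(=S)NO)c5cc(C)ccc54)C(C)C3)c(F)c21` gives 244000 nM
Compound 2 `O=C1/C(=N\NC(=S)NO)c2cc(Cl)ccc2N1CN1CCN(c2ccccc2)CC1` gives 273000 nM

Compound 1 stands at 244000 nM on this short scale, and its number and that of compound 2 lie within the scatter of each other, so neither compound stands apart. Compound 3 `CCn1cc(C(=O)O)c(=O)c2cc(F)c(N3CCN(CN4C(=O)/C(=N\NC(=S)NO)c5cc(F)ccc54)C(C)C3)c(F)c21` has not yet been measured. It departs from compound 1 in one place, with fluoro in place of methyl on an aromatic carbon (the count is fluoro in place of methyl on an aromatic carbon in full). Within the data shown here, no pair of measured compounds differs in one place, so the data hold no direct precedent for this change. Among the measured compounds shown here, the only guide is the close agreement of the two measured numbers. The expected 1.0-fold higher number from compound 1 to compound 3 (0.01 log units; within the scatter) in this assay is none beyond the scatter. For compound 3 the estimated value is 250000 nM (expected range 130000 nM to 420000 nM).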

Compound 3, half-maximal cytotoxic concentration: 187000 nM
The estimate for compound 3 lay 1.3-fold (0.13 log units) above the measured number; measured number inside the range.
By their numbers in this assay, from the lowest: compounds 3, 1 and 2 (each within the scatter of the next).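

In this assay, among these compounds, the exchange of methyl for fluoro gives a 1.3-fold lower number from compound 1 to compound 3 (0.12 log units; within the scatter) and provides the first step in this set between compounds that differ in one place. At this aromatic carbon, meta to a fused ring and para to a fused ring, the change therefore gives no step beyond the scatter, with the rest of the structure of compound 1 held constant. Nothing measured here gives a reason for this result.

The compounds shown leave open whether a methoxy group, an amine or a nitrile on this same carbon would give a number beyond the scatter of compound 1. They also leave open whether fluoro in place of methyl would give a similar step on a different core.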